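This account rests on a few compounds, and the source may have more. Where it says the series, first, only, none or still open, it means among the compounds named here.

Compound 1 `Cc1cc2nc(N3CCC(Oc4ccc(F)cc4F)CC3)c(NC3CC3)nc2cn1` and compound 2 `Cc1cc2nc(N3CCC(Oc4ccc(F)cc4F)CC3)c(NC(C)C)nc2cn1` share one core, while compound 3 `CC(=O)N1C=Cc2nc(N3CCC(Oc4ccc(F)cc4F)CC3)c(NC3CC3)nc2C1` and compound 4 `CC(=O)N1C=Cc2nc(N3CCC(Oc4ccc(F)cc4F)CC3)c(NC(C)C)nc2C1` share another; how the two cores differ is not broken down here. In a functional assay on CHO-K1 cells for agonist activity at G-protein coupled receptor 6 (Homo sapiens), read by TR-FRET and cAMP accumulation, with a stated time of 20 h (a higher number here means that more compound is needed for the effect, a lower number that less compound is needed), compound 1 gives 95000 nM. Compound 2 differs from compound 1 in a single place: isopropyl in place of cyclopropyl on a nitrogen on an aromatic ring. In this assay compound 2 gives 61000 nM, and the step is a 1.6-fold lower number from compound 1 to compound 2 (0.19 log units; within the scatter). Compound 3, on the second core, gives 43000 nM in this assay. Compound 4 differs from compound 3 in the same way: isopropyl in place of cyclopropyl on a nitrogen on an aromatic ring. Because the same change between compound 1 and compound 2 gave a 1.6-fold lower number from compound 1 to compound 2 (0.19 log units; within the scatter), a step of much the same size is expected here, and the estimated step is a 1.5-fold lower number from compound 3 to compound 4 (0.19 log units; within the scatter). Since that earlier step sits within the scatter, the expected move is small, and the estimate for compound 4 in this assay is 28000 nM, with a likely range from 15000 nM to 55000 nM. For the measured compounds named here, only one earlier example of this change exists, so the expectation rests on a thin base.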

Compound 4, half-maximal effective concentration: 34000 nM
Beside the measured number, compound 4's estimate is 1.2-fold (0.08 log units) below it, and the stated range covers the measured number.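

In this assay, the swap of cyclopropyl for isopropyl on the nitrogen gives a 1.3-fold lower number from compound 3 to compound 4 (0.10 log units; within the scatter) on the second core, so this step, like the earlier one, is no larger than repeat measurements would normally vary. Set side by side, the two steps do not differ, and the change carries over from one core to the other in these two cases: the same change on two cores in this assay, a 1.6-fold lower number (0.19 log units; within the scatter) from compound 1 to compound 2 and a 1.3-fold lower number (0.10 log units; within the scatter) from compound 3 to compound 4, 1.2-fold (0.09 log units) apart, within the scatter of two such steps This shows only that the swap has no clear effect on the number on either core; it does not show that isopropyl is truly better than cyclopropyl, and two pairs cannot establish a rule for other cores in the series.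

The compounds shown leave open whether a clearly different group on that nitrogen, such as a longer chain, a benzyl group or a chain ending in an amine, would give a step beyond the scatter. They also leave open whether such a step would carry over between the two cores as this one does.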